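Quinoline ether amides: benzyloxy for fluoro on the core

The compounds below may be only part of what the source reports. "The series", "measured", "known", "first", "only" and "open" are said of these compounds alone.

Compound 2 `Cc1cc(C)cc(NC(=O)COc2cc(C)nc3ccc(F)cc23)c1` gives 5.79 in a physicochemical assay for lipophilicity, read by HPLC, in phosphate buffer, measured as chromatographic lipophilicity, at pH 7.4; on this read-out higher numbers stand for higher lipophilicity and lower numbers for lower lipophilicity. Compound 1 `COc1ccc2c(OCC(=O)Nc3cc(C)cc(C)c3)cc(C)nc2c1` gives 5.59 in this assay, within the scatter of compound 2. Compound 3 `COc1cc2nc(C)cc(OCC(=O)Nc3cc(C)cc(C)c3)c2cc1OC` gives 4.84, lower than both. Among the measured compounds shown here, the only one-place step among the measured compounds is a number 0.75 log units lower from compound 1 to compound 3 (beyond the scatter), a modest drop beyond the scatter.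

Compound 4 `Cc1cc(C)cc(NC(=O)COc2cc(C)nc3ccc(OCc4ccccc4)cc23)c1` is not yet measured. Relative to compound 2 the change is benzyloxy in place of fluoro on an aromatic carbon. The measured step from compound 1 to compound 3 put a methoxy onto the same core and lowered the read-out, but it bears on the present change only loosely: here fluoro leaves rather than hydrogen, and what enters is a benzyloxy with its six-membered carbon ring, far larger than a methoxy. For the measured compounds named here, no measured pair covers such an addition, so the methoxy step is not taken as a guide to direction.

Given that the entering group is much larger than the leaving fluoro, compound 4 is expected to give a clearly higher number in this assay, by an estimated a number 1.11 log units higher from compound 2 to compound 4 (beyond the scatter). Compound 4 is estimated at 6.9, with a range from 6.3 to 7.5.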

Compound 4, distribution coefficient: 7.03
Compound 4: middle estimate off by 0.13 log units, on the low side, and the stated range covers the measured number.
By their numbers in this assay, from the lowest: compound 3; then compounds 1 and 2 (each within the scatter of the next); then compound 4.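

Among the compounds shown here, this position on the shared core tolerates a far larger group than fluoro, and this assay gives a large upward move with a number 1.24 log units higher from compound 2 to compound 4 (beyond the scatter), the first step to raise the number. The same ring carbon also carries the methoxy that enters in a number 0.75 log units lower from compound 1 to compound 3 (beyond the scatter), so the two steps at this place run in opposite directions, although they start from different groups and the core of compound 1 already holds a second methoxy. No measurement at hand explains the size of the rise or the opposite directions of these two steps.

The compounds shown leave open how much of the rise goes with the oxygen link, how much with the carbon ring of the benzyloxy, and whether a directly attached phenyl or a plain ethoxy at this carbon would move the number the same way. They also leave open how an amine or a carboxylic acid at this place would read at the same pH, and whether a longer chain between the oxygen and the ring would carry the number further.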